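Chloro for bromo on the fused ring of compound 1

The source may hold more compounds than are shown below. What is called first, only, known or untested is meant among the compounds shown, and "the series" means these compounds.

Compound 1 `O=C(/C=C/c1ccc(CN2C(=O)/C(=C3\Nc4ccccc4\C3=N/O)c3cc(Br)ccc32)cc1)NO` is the reference for this step. In a functional assay on SW-620 cells (Homo sapiens) for cytotoxicity, read by colorimetric assay (on this read-out higher numbers stand for weaker inhibition and lower numbers for stronger inhibition), compound 1 gives 60 nM, level at the digits shown with compound 3 `O=C(/C=C/c1ccc(CN2C(=O)/C(=C3\Nc4ccccc4\C3=N/O)c3cccc(Cl)c32)cc1)NO`, which gives 60 nM; together these are the lowest two of the three numbers. Among the compounds with values here, compound 2 `O=C(NO)c1ccc(CN2C(=O)/C(=C3\Nc4ccccc4\C3=N/O)c3cc(Br)ccc32)cc1` gives 70 nM, and the only single-point step measured so far, a 1.2-fold higher number from compound 1 to compound 2 (0.07 log units; within the scatter), concerns the hydroxamate side of the molecule and stays within the scatter.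

Compound 4 `O=C(/C=C/c1ccc(CN2C(=O)/C(=C3\Nc4ccccc4\C3=N/O)c3cc(Cl)ccc32)cc1)NO` differs from compound 1 by chloro in place of bromo on an aromatic carbon. Within the data shown here, no measured step swaps one halogen for another at this place, so there is nothing directly to lean on. Among the measured compounds shown here, what the numbers do show is that compound 3, which carries chloro and no bromo, and compound 1 sit together, and that the one measured change elsewhere left the number where it was. The expectation is therefore no step beyond the scatter, a 1.1-fold higher number from compound 1 to compound 4 (0.03 log units; within the scatter). Compound 4 is estimated at 65 nM, with a range from 35 nM to 120 nM.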

Compound 4, half-maximal inhibitory concentration: 80 nM
Compound 4: middle estimate off by 1.2-fold (0.09 log units), on the low side, and the stated range covers the measured number.
By their numbers in this assay, from the lowest: compounds 1, 3, 2 and 4 (each within the scatter of the next).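

In this assay, chloro in place of bromo on an aromatic carbon gives a 1.3-fold higher number from compound 1 to compound 4 (0.12 log units; within the scatter), so this read-out does not separate the two halogens at this place. The earlier compounds showed only a change on the hydroxamate side of the molecule; this is the one step shown at the fused ring itself, and it too stays within the scatter. No accompanying measurement offers an explanation for this step.

Still open, on these data alone, is whether this place stays as undemanding with something other than a halogen, such as a hydrogen, a methoxy group, an amine or a carboxylic acid. Also open, as far as these compounds go, is whether the halogen exchange behaves the same way when the hydroxycarbamoyl group of compound 2 replaces the 2-(hydroxycarbamoyl)ethenyl group.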